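Pyrimidine in place of pyridine on the vinyl sulfone

The source may report more compounds than this note shows. Statements on the series, on what has been measured and on what is new or still open speak of the compounds shown alone.

Compound 1 `COc1ccc(S(=O)(=O)/C=C/c2cccnc2)cc1` gives 85.8% in an ADME assay on BV-2 cells (Mus musculus) for cytotoxicity, with a stated time of 24 h, tested at 50 uM; a higher number here means a weaker effect of the compound at the concentration tested, a lower number a stronger effect. Its neighbours in the series are compound 2 `COc1ccc(S(=O)(=O)/C=C/c2cccnc2Cl)cc1`, which gives 76.3%, and compound 3 `COc1ccc(S(=O)(=O)/C=C/c2ccc(F)nc2)cc1`, which gives 95.7%; the steps are a number 9.5 percentage points lower from compound 1 to compound 2 (within the scatter) and a number 9.9 percentage points higher from compound 1 to compound 3 (within the scatter), so all three numbers sit together. Compound 4 `COc1ccc(S(=O)(=O)/C=C/c2cncnc2)cc1` differs from compound 1 by pyrimidin-5-yl in place of pyridin-3-yl on a double-bonded chain carbon bound to a double-bonded chain carbon. Neither measured step changes the ring itself; both only add a halogen to it and stay within the scatter. Among the measured compounds shown here, no step bears directly on the ring change, so no shift beyond the scatter is expected in this assay. The estimate for compound 4 is therefore 86%, with a range of 70% to 100%, meaning an expected step of a number 0.2 percentage points higher from compound 1 to compound 4 (within the scatter).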

Compound 4, a percentage reported as activity, at one concentration (the size of the read-out at that concentration, not a potency): 100%
Compound 4: middle estimate off by 14 percentage points, on the low side; the range from low to high includes it.
By their numbers in this assay, from the lowest: compounds 2, 1, 3 and 4 (each within the scatter of the next, the first and the last beyond it).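

Pyrimidin-5-yl in place of pyridin-3-yl on a double-bonded chain carbon bound to a double-bonded chain carbon gives, in this assay, a number 14.2 percentage points higher from compound 1 to compound 4 (beyond the scatter) and so points to a weaker effect at the concentration tested. Among the compounds shown here, this is the first single change to pass the scatter, as the chloro and fluoro steps on pyridin-3-yl both stay within it. Nothing available bears on why the ring change has this effect.

On these data alone, whether phenyl at the same place would read with compound 1 or with compound 4 stays open. Also open, as far as these compounds go, is whether an amine on pyrimidin-5-yl would keep the number of compound 4.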